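The source may hold more compounds than are shown below. What is called first, only, known or untested is meant among the compounds shown, and "the series" means these compounds.

Measured compounds:
compound 1, `COc1cc(CNC(=S)NC(CCc2ccc(C(C)(C)C)cc2)COC(=O)C(C)(C)C)ccc1O` — 36.5 nM
compound 2, `COc1cc(CNC(=S)NCC(COC(=O)C(C)(C)C)Cc2ccc(C(C)(C)C)cc2)cc(Cl)c1O` — 21.3 nM

Both compounds were measured in an assay on CHO cells for displacement of a labelled ligand from transient receptor potential cation channel subfamily V member 1 (Rattus norvegicus); on this read-out lower numbers stand for stronger inhibition and higher numbers for weaker inhibition. Compound 2 gives the lower of the two numbers, yet its gap to compound 1 lies within the usual scatter, so the two cannot be told apart on these data. Compound 3, `COc1cc(CNC(=S)NCC(COC(=O)C(C)(C)C)Cc2ccc(C(C)(C)C)cc2)c(I)cc1O`, has not been measured. It differs from compound 2 in one place: 4-hydroxy-2-iodo-5-methoxyphenyl in place of 3-chloro-4-hydroxy-5-methoxyphenyl on a saturated chain carbon bound to an amide-type nitrogen. The chlorine is replaced by an iodine, and the group named by the difference changes accordingly, while the rest of the structure, including the shared core, stays the same. Within the data shown here, no measured pair shows a halogen exchange of this kind, so the direction of the step in this assay is not known from the data. Compound 3 is expected to land close to compound 2, with a step of a 1.3-fold higher number from compound 2 to compound 3 (0.12 log units; within the scatter) that stays within the scatter. The estimate for compound 3 is 28 nM, within a range from 9 nM to 90 nM.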

Compound 3, inhibition constant: 13.3 nM
Estimate against measurement, compound 3: 2.1-fold (0.32 log units) above, and the stated range covers the measured number.
By their numbers in this assay, from the lowest: compounds 3, 2 and 1 (each within the scatter of the next, the first and the last beyond it).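

Among these compounds, replacing 3-chloro-4-hydroxy-5-methoxyphenyl with 4-hydroxy-2-iodo-5-methoxyphenyl on a saturated chain carbon bound to an amide-type nitrogen gives the first direct reading of a halogen exchange at this position in this assay: a 1.6-fold lower number from compound 2 to compound 3 (0.20 log units; within the scatter). The two compounds cannot be told apart on this read-out, so this position accepts the iodine-bearing group in place of the chlorine-bearing one without a clear loss or gain, although the group names show that the halogen's position number changes along with the element. No measured property of either group is available to account for this result.

Going by these compounds, how much of the step belongs to the element and how much to its position remains open. It is also unknown whether bromine or fluorine in place of the iodine, or an amine in place of the hydroxy group, would hold the number in this range.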